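Methyl to methoxy exchange across two cores

The source may hold more compounds than are shown below. What is called first, only, known or untested is meant among the compounds shown, and "the series" means these compounds.

Measured in a functional assay on MCF7 cells (Homo sapiens) for inhibition, read by colorimetric assay and MTT assay, with a stated time of 72 h; a higher number here means a weaker inhibitor, a lower number a stronger inhibitor:
compound 1 `COc1ccc(-c2cc(NC(=S)NNC(=O)c3ccc(C)cc3)cs2)cc1` gives 40000 nM
compound 2 `Cc1ccc(C(=O)NNC(=S)Nc2csc(-c3ccc(C)cc3)c2)cc1` gives 29000 nM
compound 3 `Cc1ccc(-c2nnc(Nc3csc(-c4ccccc4)c3)s2)cc1` gives 34000 nM

All three numbers lie close together, within the scatter of one another, so no order among them is claimed. Among the measured compounds shown here, the one single-point change that is measured, (methoxy in place of methyl on an aromatic carbon), gave a 1.4-fold higher number from compound 2 to compound 1 (0.14 log units; within the scatter). The difference between the core of compound 2 and the core of compound 3 is not broken down here.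

Compound 4 `COc1ccc(-c2nnc(Nc3csc(-c4ccccc4)c3)s2)cc1` has not been measured. It differs from compound 3 by methoxy in place of methyl on an aromatic carbon, the same change as from compound 2 to compound 1, at the same kind of place. For the measured compounds named here, the step is expected to be a 1.2-fold higher number from compound 3 to compound 4 (0.09 log units; within the scatter), of about the size seen in a 1.4-fold higher number from compound 2 to compound 1 (0.14 log units; within the scatter), since that is the only measured instance of this change. Compound 4 is therefore estimated at 42000 nM in this assay, with a range from 20000 nM to 90000 nM.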

Compound 4, half-maximal inhibitory concentration: 60000 nM
For compound 4 the middle estimate is 1.4-fold (0.15 log units) below the measured one; measured number inside the range.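

In this assay methoxy in place of methyl on an aromatic carbon gave a 1.8-fold higher number from compound 3 to compound 4 (0.25 log units; within the scatter) and so stays within the scatter on this core. Neither core shows a step beyond the scatter, so a real effect of the exchange is not shown on either, and two pairs set no rule for other cores in the series. As far as these two pairs can tell, the change carries from one core to the other without a difference between the steps: the same change on two cores in this assay, a 1.4-fold higher number (0.14 log units; within the scatter) from compound 2 to compound 1 and a 1.8-fold higher number (0.25 log units; within the scatter) from compound 3 to compound 4, 1.3-fold (0.11 log units) apart, within the scatter of two such steps

The compounds shown leave open what other groups would do at this place, such as an amine, a carboxylic acid or a longer chain. Going by these compounds, whether any of these would move the number beyond the scatter on either core also remains open.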